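A few compounds are considered here, and "the series" means these few. Any claim that something is new, unique, unknown or untested is made for them only; others in the source may bear on it.

Working notes on a thiazolidinedione series in a functional assay on MCF7 cells (Homo sapiens), tested at 7.5 uM; on this read-out lower numbers stand for a stronger effect and higher numbers for a weaker effect at the one concentration tested.

Compound 1 `CC(C)=CCOc1c(C)c(C)c2c(c1C)CCC(C)(COc1ccc(/C=C3\SC(=O)NC3=O)cc1C)O2` gives 27% in this assay. Compound 2 `C=CCOc1c(C)c(C)c2c(c1C)CCC(C)(COc1ccc(/C=C3\SC(=O)NC3=O)cc1C)O2` gives 8% in this assay, and compound 3 `C=CCOc1c(C)c(C)c2c(c1C)CCC(C)(COc1ccc(/C=C3\SC(=O)NC3=O)cc1Br)O2` gives 105% in this assay. Compound 4 `CC(C)=CCOc1c(C)c(C)c2c(c1C)CCC(C)(COc1ccc(/C=C3\SC(=O)NC3=O)cc1Br)O2` is not yet measured.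

Two measured steps frame the set. Between compound 2 and compound 1 the change is 2-methylprop-1-en-1-yl in place of vinyl on a saturated chain carbon bound to an oxygen on an aromatic ring, and in this assay it gave a number 19 percentage points higher from compound 2 to compound 1 (beyond the scatter). Between compound 2 and compound 3 the change is bromo in place of methyl on an aromatic carbon, and in this assay it gave a number 97 percentage points higher from compound 2 to compound 3 (beyond the scatter). Compound 3 thus stands highest of the three, beyond the scatter from compound 1 and from compound 2.

Compound 4 is reached from compound 3 by 2-methylprop-1-en-1-yl in place of vinyl on a saturated chain carbon bound to an oxygen on an aromatic ring. This is the same change as from compound 2 to compound 1: the place lines read alike word for word. The two cores, however, differ by the bromo in place of methyl told above, so the step is transferred across that difference. In compound 2 the change weakened the read-out by a modest amount. Compound 3 already sits at a level where little effect is seen, as compound 3 gives 105% in this assay. So the expected step from compound 3 to compound 4 in this assay is no change at the digits printed from compound 3 to compound 4 (within the scatter), essentially flat, resting on that level of compound 3 and on the size of a number 19 percentage points higher from compound 2 to compound 1 (beyond the scatter). Compound 4 is therefore expected to give about 105% in this assay, estimated between 90% and 125%.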

Compound 4, a percentage reported as activity, at one concentration (the size of the read-out at that concentration, not a potency): 53%
Estimate against measurement, compound 4: 52 percentage points above; measured number below the stated range.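

Carried onto the core bearing bromo, the change from allyl to 3-methylbut-2-en-1-yl gave a number 52 percentage points lower from compound 3 to compound 4 (beyond the scatter) in this assay, opposite in direction to the step on the core bearing methyl: the same change on two cores in this assay, a number 19 percentage points higher (beyond the scatter) from compound 2 to compound 1 and a number 52 percentage points lower (beyond the scatter) from compound 3 to compound 4, 71 percentage points apart, beyond the scatter of two such steps. Read the other way, bromo in place of methyl on the 3-methylbut-2-en-1-yl side gave a number 26 percentage points higher from compound 1 to compound 4 (beyond the scatter), a rise in the same direction as on the allyl side but much smaller: the same change on two cores in this assay, a number 97 percentage points higher (beyond the scatter) from compound 2 to compound 3 and a number 26 percentage points higher (beyond the scatter) from compound 1 to compound 4, 71 percentage points apart, beyond the scatter of two such steps. Within these four compounds the two changes therefore do not add, and a step measured on one core cannot simply be transferred to the other, though the data do not show why this is so or whether the same holds for any other pair of changes in the series.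

The compounds shown leave open whether this dependence extends to other groups, such as chloro on that aromatic carbon, or benzyl or a longer chain on the ether oxygen in place of allyl. They also leave open whether the order seen at the one concentration tested would hold as a difference in potency.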